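From 2-methylphenyl to 4-ethylphenyl on the shared core

The compounds below may be only part of what the source reports. "The series", "measured", "known", "first", "only" and "open" are said of these compounds alone.

Measured in a functional assay on HCT-116 cells (Homo sapiens) for antiproliferative activity, read by radiometric assay, with a stated time of 72 h; a lower number here means a stronger inhibitor, a higher number a weaker inhibitor:
- compound 1 `Cc1ccccc1Nc1ncnc2cc(NC(=O)CCCCCCC(=O)NO)sc12`: 2560 nM
- compound 2 `Cc1ccc(F)c(Nc2ncnc3cc(NC(=O)CCCCCCC(=O)NO)sc23)c1`: 1330 nM
- compound 3 `C#Cc1cccc(Nc2ncnc3cc(NC(=O)CCCCCCC(=O)NO)sc23)c1`: 1010 nM

Compound 1, at 2560 nM, holds the highest of the three numbers. Compound 4 `CCc1ccc(Nc2ncnc3cc(NC(=O)CCCCCCC(=O)NO)sc23)cc1`, not yet measured, carries 4-ethylphenyl in place of 2-methylphenyl on a nitrogen on an aromatic ring. Two measured steps replace the same group: a 1.9-fold lower number from compound 1 to compound 2 (0.28 log units; within the scatter) and a 2.5-fold lower number from compound 1 to compound 3 (0.40 log units; beyond the scatter). The remaining step, a 1.3-fold lower number from compound 2 to compound 3 (0.12 log units; within the scatter), separates those two replacements. Neither replacement is 4-ethylphenyl, so these steps offer only indirect guidance, and a small drop, probably none beyond the scatter, is expected. The estimated step is a 1.7-fold lower number from compound 1 to compound 4 (0.23 log units; within the scatter). Compound 4 is expected at 1500 nM, with an estimated range of 650 nM to 3400 nM.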

Compound 4, half-maximal inhibitory concentration: 2360 nM
Estimate against measurement, compound 4: 1.6-fold (0.20 log units) below, and the stated range covers the measured number.
By their numbers in this assay, from the lowest: compounds 3, 2, 4 and 1 (each within the scatter of the next, the first and the last beyond it).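

In this assay, 4-ethylphenyl on the nitrogen cannot be told apart from 2-methylphenyl (a 1.1-fold lower number from compound 1 to compound 4 (0.04 log units; within the scatter)) or from 2-fluoro-5-methylphenyl (a 1.8-fold higher number from compound 2 to compound 4 (0.25 log units; within the scatter)). Among these compounds, only the step to this group from 3-ethynylphenyl (a 2.3-fold higher number from compound 3 to compound 4 (0.37 log units; beyond the scatter)) passes the scatter, so 3-ethynylphenyl now stands apart from both 2-methylphenyl and 4-ethylphenyl, though not from 2-fluoro-5-methylphenyl. Nothing available explains these differences. As far as these compounds go, whether an amine or a carboxylic acid on the phenyl ring would move the number further stays open. So does whether a propyl group would differ from 4-ethylphenyl.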